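Acid dissociation across the side-chain aryl exchanges

The source may hold more compounds than are shown below. What is called first, only, known or untested is meant among the compounds shown, and "the series" means these compounds.

Compound 3 `COc1cccc(CNCCCNc2ccnc3cc(-c4ccc(F)cc4)ccc23)c1O` gives 9.47 in a physicochemical assay for acid dissociation. Compound 1 `COc1cccc(CNCCCNc2ccnc3cc(Cc4ccccc4)ccc23)c1O` gives 9.47, and compound 2 `COc1cccc(CNCCCNc2ccnc3cc(Oc4ccc(F)cc4)ccc23)c1O` gives 9.28. Compound 3 stands level with compound 1, the two together the highest of the three numbers, while no change at the digits printed from compound 1 to compound 3 (within the scatter), a number 0.19 log units lower from compound 1 to compound 2 (within the scatter) and a number 0.19 log units higher from compound 2 to compound 3 (within the scatter) all lie within the scatter. Compound 4 `COc1cccc(CNCCCNc2ccnc3cc(Cc4cc(C)cc(C)c4)ccc23)c1O` has not been measured. (3,5-dimethylbenzyl in place of 4-fluorophenyl on an aromatic carbon). The step that bears most directly on this exchange is the one from benzyl to 4-fluorophenyl, no change at the digits printed from compound 1 to compound 3 (within the scatter), and the other exchanges at the same aromatic carbon moved the number by no more than the scatter. No step beyond the scatter is therefore expected in this assay for compound 4, with no change at the digits printed from compound 3 to compound 4 (within the scatter) as the expected step. Compound 4 is estimated at 9.47, in the range 9.17 to 9.77.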

Compound 4, acid dissociation constant: 9.47
Compound 4: middle estimate and measured number agree at the digits printed, within the range that was stated.
By their numbers in this assay, from the lowest: compounds 2, 1, 3 and 4 (each within the scatter of the next).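

In this assay, 3,5-dimethylbenzyl on this aromatic carbon stays within the scatter of all three earlier groups (no change at the digits printed from compound 3 to compound 4 (within the scatter)) (a number 0.19 log units higher from compound 2 to compound 4 (within the scatter)). The new information is that substitution on the benzyl ring itself, 3,5-dimethylphenyl in place of phenyl, also stays within the scatter (no change at the digits printed from compound 1 to compound 4 (within the scatter)). No evidence is available to account for this result.

On these data alone, whether an amine or a carboxylic acid on this aromatic carbon would give a step beyond the scatter remains open. As far as these compounds go, the reading with a plain hydrogen there is also open.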